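This account rests on a few compounds, and the source may have more. Where it says the series, first, only, none or still open, it means among the compounds named here.

Compound 1 `N#Cc1cnc(NCc2cnccc2C(F)(F)F)cc1N[C@H]1CC[C@H](O)CC1` in an assay on isolated protein for inhibition of protein kinase C delta type (Homo sapiens), read by TR-FRET, with a stated time of 2 h (on this read-out lower numbers stand for stronger inhibition and higher numbers for weaker inhibition), gives 6500 nM, the highest of the two numbers in hand. Compound 2 `COc1ncncc1CNc1cc(N[C@H]2CC[C@@H](O)CC2)c(C#N)cn1` gives 800 nM in this assay, and its gap from compound 1 lies beyond the scatter. Compound 3 `CC1(C)C[C@@H](Nc2cc(NCc3cnccc3C(F)(F)F)ncc2C#N)CC[C@H]1O` is not yet measured. It differs from compound 1 in one place: 4-hydroxy-3,3-dimethylcyclohexyl in place of 4-hydroxycyclohexyl on a nitrogen on an aromatic ring. Among the compounds with values here, no measured pair shows this change, so no step can be read from the numbers in hand. The expected step, a 1.6-fold lower number from compound 1 to compound 3 (0.21 log units; within the scatter), is small and within the scatter, with no clear direction. Compound 3 is estimated at 4000 nM, with a range from 1500 nM to 12000 nM.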

Compound 3, half-maximal inhibitory concentration: 2400 nM
Compound 3: middle estimate off by 1.7-fold (0.22 log units), on the high side; low and high end bracket the measured number.
By their numbers in this assay, from the lowest: compound 2; then compound 3; then compound 1.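

On the shared core, this position accepts the larger ring substituent without loss: in this assay, 4-hydroxy-3,3-dimethylcyclohexyl in place of 4-hydroxycyclohexyl gives a 2.7-fold lower number from compound 1 to compound 3 (0.43 log units; beyond the scatter). Within the data shown here, this is the first readable change at this position, and it runs toward stronger inhibition, though only modestly. Nothing in hand gives a reason for the step. Open, on these data alone, is whether a single methyl on the ring, or an amine in place of the hydroxyl, would give a similar step. Also open, as far as these compounds go, is whether the same change carries over to the core of compound 2.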